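This account rests on a few compounds, and the source may have more. Where it says the series, first, only, none or still open, it means among the compounds named here.

Compound 1 `COc1ccc(CNCCCNS(=O)(=O)c2cc(C(F)(F)F)cc(C(F)(F)F)c2)cc1OC` gives 18000 nM in a functional assay on PANC-1 cells (Homo sapiens) for inhibition, read by MTT assay, with a stated time of 72 h (on this read-out lower numbers stand for stronger inhibition of growth and higher numbers for weaker inhibition of growth), and stands highest of the three measured numbers. Compound 2 `O=S(=O)(NCCCNCc1cccc(Cl)c1)c1cc(C(F)(F)F)cc(C(F)(F)F)c1` gives 12000 nM, a step of a 1.5-fold lower number from compound 1 to compound 2 (0.18 log units; within the scatter). Compound 3 `O=S(=O)(NCCCNCC1COc2ccccc2O1)c1cc(C(F)(F)F)cc(C(F)(F)F)c1` gives 3400 nM, a step of a 5.3-fold lower number from compound 1 to compound 3 (0.72 log units; beyond the scatter), and from compound 2 a step of a 3.5-fold lower number from compound 2 to compound 3 (0.55 log units; beyond the scatter). Compound 4 `O=S(=O)(NCCCNCc1ccccc1)c1cc(C(F)(F)F)cc(C(F)(F)F)c1` differs from compound 1 by phenyl in place of 3,4-dimethoxyphenyl on a saturated chain carbon bound to an amine nitrogen. The step from compound 1 to compound 2, where another six-membered aromatic ring of carbon only replaced the 3,4-dimethoxyphenyl group, stayed within the scatter; the larger drop appeared only with the 2,3-dihydro-1,4-benzodioxin-2-yl group of compound 3. Compound 4 is therefore expected to show a 1.4-fold lower number from compound 1 to compound 4 (0.14 log units; within the scatter), nothing beyond the scatter. The estimated number of compound 4 in this assay is 13000 nM, with a range from 5500 nM to 30000 nM.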

Compound 4, concentration for 50% growth inhibition: 16000 nM
The estimate for compound 4 lay 1.2-fold (0.09 log units) below the measured number; the measured number falls inside the stated range.
By their numbers in this assay, from the lowest: compound 3; then compounds 2, 4 and 1 (each within the scatter of the next).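

In this assay, groups on the aromatic ring at this place leave no readable difference: phenyl in place of 3,4-dimethoxyphenyl gives a 1.1-fold lower number from compound 1 to compound 4 (0.05 log units; within the scatter), and hydrogen in place of chloro gives a 1.3-fold higher number from compound 2 to compound 4 (0.12 log units; within the scatter). Phenyl in place of 2,3-dihydro-1,4-benzodioxin-2-yl gives a 4.7-fold higher number from compound 3 to compound 4 (0.67 log units; beyond the scatter), so among these compounds only that group stands apart from plain phenyl. Nothing measured here accounts for this. From the compounds shown here alone, whether a cyclohexyl group or a pyridine ring at this place would match compound 3 remains open.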